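Solubility of a Shared Amide Core with Varied Benzylic Groups

A few compounds are considered here, and "the series" means these few. Any claim that something is new, unique, unknown or untested is made for them only; others in the source may bear on it.

Measured compounds:
Compound 1 `CNC(=O)c1cc(C(=O)NC2CC2)cn(Cc2cccc(OC)c2)c1=O` — 582 ug/mL
Compound 2 `CNC(=O)c1cc(C(=O)NC2CC2)c(C)n(Cc2ccccc2)c1=O` — 577 ug/mL
Compound 3 `CNC(=O)c1cc(C(=O)NC2CCC2)cn(Cc2ccccc2)c1=O` — 24 ug/mL

In a physicochemical assay for solubility, read by HPLC, in simulated intestinal fluid, with a stated time of 16 h, tested at 125 ug/mL (a lower number here means a less soluble compound, a higher number a more soluble compound), compound 1 gives 582 ug/mL, the highest of the three numbers. Compound 2 gives 577 ug/mL, which lies within the scatter of compound 1, so the two cannot be placed in order. Compound 3 gives 24 ug/mL, and its gap to compound 1 lies beyond the scatter.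

Compound 4 `CNC(=O)c1cc(C(=O)NC2CC2)cn(Cc2cccc3cc[nH]c23)c1=O` has not yet been measured in this assay. It differs from compound 1 in one place: 1H-indol-7-yl in place of 3-methoxyphenyl on a saturated chain carbon bound to an aromatic nitrogen. Going by the values given here, no measured pair shows this change, so its size is not known from the data. A decrease beyond the scatter is expected, and the step of a 3.9-fold lower number from compound 1 to compound 4 (0.59 log units; beyond the scatter) is an estimate. Compound 4 is expected to give about 150 ug/mL, with a range from 40 ug/mL to 500 ug/mL.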

Compound 4, solubility: 11 ug/mL
Estimate against measurement, compound 4: 14-fold (1.13 log units) above, outside the stated range (below it).
By their numbers in this assay, from the lowest: compound 4; then compound 3; then compounds 2 and 1 (each within the scatter of the next).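

In this assay, the first single-place comparison gives a 53-fold lower number from compound 1 to compound 4 (1.72 log units; beyond the scatter), with 1H-indol-7-yl in place of 3-methoxyphenyl on a saturated chain carbon bound to an aromatic nitrogen. Going by these compounds alone, the number at this place therefore depends strongly on the group it carries, which the earlier compounds, differing in more than one place, could not show. Nothing at hand bears on why the number falls with this change. Still open, as far as these compounds go, is how an amine or a carboxylic acid on the aromatic ring at this place would read.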